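This account rests on a few compounds, and the source may have more. Where it says the series, first, only, none or still open, it means among the compounds named here.

Measured so far in this series:
compound 1, `COc1nc2ccc(Br)cc2cc1C(c1ccccc1)n1cc(-c2ccc(Br)cc2)nn1`: 6.92%
compound 2, `CCCCc1cn(C(c2ccccc2)c2cc3cc(Br)ccc3nc2OC)nn1`: -2.87%
compound 3, `CCCCCCCCc1cn(C(c2ccccc2)c2cc3cc(Br)ccc3nc2OC)nn1`: 0.1%

In an ADME assay on HeLa cells (Homo sapiens) for cytotoxicity, read by sulforhodamine B assay, with a stated time of 48 h, tested at 10 uM (a higher number here means more inhibition at the concentration tested (going by the name of the read-out), a lower number less inhibition), compound 3 stands second highest of the three numbers. Its nearest neighbour is compound 2 (a number 3 percentage points higher from compound 2 to compound 3 (within the scatter)) and its furthest is compound 1 (a number 6.8 percentage points lower from compound 1 to compound 3 (within the scatter)); both gaps sit within the scatter, so no order among the three can be claimed.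

Compound 4, `COc1nc2ccc(Br)cc2cc1C(c1ccccc1)n1cc(-c2ccccc2C(F)(F)F)nn1`, is still to be measured in this assay. It differs from compound 3 by 2-(trifluoromethyl)phenyl in place of octyl on an aromatic carbon. The step that bears most directly on this change is the reverse of a number 6.8 percentage points lower from compound 1 to compound 3 (within the scatter), in which an aromatic ring on that aromatic carbon was traded for octyl; a number 9.8 percentage points lower from compound 1 to compound 2 (within the scatter) points the same way for butyl. Neither of those steps left the scatter, so putting an aromatic ring back in place of the octyl chain is expected to shift the number by little, if anything, and if anything upward. The estimate for compound 4 in this assay is 4%, with a range from -8% to 16%, which means an expected step of a number 3.9 percentage points higher from compound 3 to compound 4 (within the scatter).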

Compound 4, a percentage reported as inhibition, at one concentration (the size of the read-out at that concentration, not a potency): -1.3%
Compound 4: middle estimate off by 5.3 percentage points, on the high side, within the range that was stated.
By their numbers in this assay, from the lowest: compounds 2, 4, 3 and 1 (each within the scatter of the next).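

In this assay, 2-(trifluoromethyl)phenyl on the aromatic carbon of the five-membered aromatic ring with 3 nitrogen cannot be told apart from octyl (a number 1.4 percentage points lower from compound 3 to compound 4 (within the scatter)) or from butyl (a number 1.6 percentage points higher from compound 2 to compound 4 (within the scatter)). Trading one aromatic ring for another, with 2-(trifluoromethyl)phenyl in place of 4-bromophenyl, also stays within the scatter (a number 8.2 percentage points lower from compound 1 to compound 4 (within the scatter)), so the hint that an aromatic ring here reads differently from a chain finds no support in compound 4. Nothing available explains this flat reading at the position.

Going by these compounds, all four compounds lie within the scatter of one another, so it remains open whether any group at this carbon can move the number at all. An amine, a carboxylic acid or a chain longer than octyl at this position would test that on the shared core.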